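A Fluorine for a Methoxy on the Hydrazone Aryl Ring

This account rests on a few compounds, and the source may have more. Where it says the series, first, only, none or still open, it means among the compounds named here.

Compound 1 `COc1cccc(/C=N\NC(=O)C2=C(Cl)c3ccccc3CCC2)c1`: < 10 nM
Compound 2 `COc1ccc(/C=N\NC(=O)C2=C(Cl)c3ccccc3CCC2)c(OC)c1`: 2700 nM

In a functional assay (MiaPaCa cells, Homo sapiens) for inhibition, read by sulforhodamine B assay, with a stated time of 48 h (on this read-out higher numbers stand for weaker inhibition of growth and lower numbers for stronger inhibition of growth), compound 1 is reported only as a limit of the assay, < 10 nM, so its true potency is not pinned down. Compound 2 gives 2700 nM in this assay. These two compounds are not linked by a single-place change, so only what each value shows can be said. Compound 3 `O=C(N/N=C\c1ccc(F)cc1)C1=C(Cl)c2ccccc2CCC1` differs from compound 1 by 4-fluorophenyl in place of 3-methoxyphenyl on a carbon with a double bond to nitrogen. For the measured compounds named here, no measured pair shows this change, so its size is unknown. Because compound 1 sits at the limit of < 10 nM in this assay, at which 1 of the 2 values shown sits, any real shift can only show up as weaker inhibition. The shift is expected to be an at least 10-fold higher number from compound 1 to compound 3 (1.00 log units; beyond the scatter), toward weaker inhibition. Compound 3 is expected to give about 100 nM, within 10 nM to 2000 nM.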

Compound 3, concentration for 50% growth inhibition: < 10 nM
Compound 3: no number, only a limit (the forecaster's own chance of this, stated with the estimate: 25%); middle value at least 10-fold (1.00 log units) away from the limit.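

In this assay compound 3 gives < 10 nM as a limit and not a number. For the compounds shown here, with compound 1 at a limit too, no step between compound 1 and compound 3 can be read: the limit of < 10 nM in this assay, at which 2 of the 3 values shown sit. The compounds shown leave open how far apart the true potencies of these two compounds lie, and whether 4-fluorophenyl in place of 3-methoxyphenyl changes growth inhibition at all.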